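A few compounds are considered here, and "the series" means these few. Any claim that something is new, unique, unknown or untested is made for them only; others in the source may bear on it.

In a functional assay on K-562R cells (Homo sapiens) for cytotoxicity, read by XTT assay, with a stated time of 24 h (on this read-out higher numbers stand for weaker inhibition and lower numbers for stronger inhibition), compound 2 `COc1ccc(C(=O)Nc2ccc(C)c(Nc3nccc(-c4cccnc4)n3)c2)cc1OCCCCn1ccnc1` gives 18700 nM. Compound 1 `Cc1ccc(NC(=O)c2ccc(OCCCCn3ccnc3)c(Br)c2)cc1Nc1nccc(-c2cccnc2)n1` gives 31800 nM in this assay, a gap from compound 2 that lies within the scatter, whereas compound 3 `Cc1ccc(NC(=O)c2ccc(OCCCCn3ccnc3)cc2)cc1Nc1nccc(-c2cccnc2)n1` gives 99400 nM, a gap beyond it. Going by the values given here, the one single-point step among the measured compounds is a 3.1-fold higher number from compound 1 to compound 3 (0.49 log units; beyond the scatter). Compound 4 `Cc1ccc(NC(=O)c2ccc([N+](=O)[O-])c(OCCCCn3ccnc3)c2)cc1Nc1nccc(-c2cccnc2)n1` differs from compound 2 by nitro in place of methoxy on an aromatic carbon. Among the compounds with values here, no measured step exchanges methoxy for nitro, and the bromo step does not concern the same group, so the data give no direct guide; a step within the scatter is therefore expected, a 1.2-fold higher number from compound 2 to compound 4 (0.07 log units; within the scatter). Compound 4 is estimated at 22000 nM in this assay, in a range from 8000 nM to 60000 nM.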

Compound 4, half-maximal inhibitory concentration: 47600 nM
Compound 4: middle estimate off by 2.2-fold (0.34 log units), on the low side, within the range that was stated.
By their numbers in this assay, from the lowest: compounds 2, 1 and 4 (each within the scatter of the next, the first and the last beyond it); then compound 3.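

In this assay the exchange on the ring carbon ortho to a 4-(1H-imidazol-1-yl)butoxy group and para to a large group gives a 2.5-fold higher number from compound 2 to compound 4 (0.41 log units; beyond the scatter) and so moves the read-out towards weaker inhibition. This shows that the read-out at this position is sensitive to the group it carries, which the bromo step, made on a different substitution pattern, could not show. No measurement here explains the step. As far as these compounds go, how an amine or a carboxylic acid at this position would compare with methoxy and nitro remains open, as does whether a longer chain in place of the 4-(1H-imidazol-1-yl)butoxy group would alter the step.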